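One ring swapped on compound 1

The source may report more compounds than this note shows. Statements on the series, on what has been measured and on what is new or still open speak of the compounds shown alone.

Compound 1 `COc1cc2[nH]c(C)c(-c3ccc(Oc4ccc(C(F)(F)F)cc4)cc3)c(=O)c2cc1Cl`: > 10000 nM
Compound 2 `COc1cc2[nH]c(C)c(-c3ccc(Oc4ccc(OC(F)(F)F)cc4)nc3)c(=O)c2cc1Cl`: > 10000 nM
Compound 3 `COc1cc2[nH]c(C)c(-c3ccc(Oc4ccc(OC(F)(F)F)cc4)cn3)c(=O)c2cc1Cl`: > 10000 nM

All three results come from an ADME assay on HepG2 cells (Homo sapiens) for cytotoxicity, read by resazurin assay, with a stated time of 24 h; a lower number here means a stronger inhibitor, a higher number a weaker inhibitor. Compound 1 gives > 10000 nM, which is a limit and not a number. It therefore has no exact place among its neighbours, and the three results share one description: the limit of > 10000 nM in this assay, at which 3 of the 3 values shown sit.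

Compound 4 `COc1cc2[nH]c(C)c(-c3ccc(Oc4ccc(C(F)(F)F)cn4)cc3)c(=O)c2cc1Cl` has not yet been measured. It keeps the core of compound 1 but carries 5-(trifluoromethyl)pyridin-2-yl in place of 4-(trifluoromethyl)phenyl on an oxygen on an aromatic ring. For the measured compounds named here, no measured pair shows a single change of this kind. Given (the limit of > 10000 nM in this assay, at which 3 of the 3 values shown sit), no step beyond the scatter is expected in this assay, and another limit is the likeliest report. The estimated change is a step that the limit leaves unreadable from compound 1 to compound 4. For compound 4 the expected value is 15000 nM, with an estimated range from 7000 nM to 30000 nM.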

Compound 4, half-maximal inhibitory concentration: > 10000 nM
Compound 4 was reported as a limit; the forecaster's own chance of this, stated with the estimate: 85%; the middle value lies beyond the limit too.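

Compound 1 and compound 4 are both reported only as limits in this assay, so no step can be read between them: the limit of > 10000 nM in this assay, at which 4 of the 4 values shown sit.

The compounds shown leave open whether this ring swap changes cytotoxicity at all.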